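Swapping a hydroxyphenyl group on a cytotoxic pyridine core

The source may report more compounds than this note shows. Statements on the series, on what has been measured and on what is new or still open speak of the compounds shown alone.

Of the compounds shown here, three sharing one core have been tested in a functional assay on HeLa cells (Homo sapiens) for cytotoxicity, read by CCK-8 assay; a lower number here means a stronger inhibitor, a higher number a weaker inhibitor. Compound 1 `Oc1cccc(-c2cc(-c3ccco3)cc(-c3cccc(O)c3)n2)c1` gives 5990 nM in this assay. Compound 2 `Oc1ccc(-c2cc(-c3ccco3)cc(-c3cccc(O)c3)n2)cc1` gives 5170 nM in this assay, and the move 4-hydroxyphenyl in place of 3-hydroxyphenyl on an aromatic carbon yields a 1.2-fold lower number from compound 1 to compound 2 (0.06 log units; within the scatter). Going by the values given here, compound 3 `Oc1ccc(-c2cc(-c3ccccn3)cc(-c3cccc(O)c3)n2)cc1` gives 1930 nM in this assay, so the step of a 2.7-fold lower number from compound 2 to compound 3 (0.43 log units; beyond the scatter) is the one change among the measured compounds that reaches beyond the scatter, making compound 3 the most potent of the three; the difference between the cores of compound 1 and compound 3 is not broken down here.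

Compound 4 `Oc1ccc(-c2cc(-c3ccccn3)cc(-c3ccc(O)cc3)n2)cc1` has not yet been measured. Among the compounds with values here, it differs from compound 3 by 4-hydroxyphenyl in place of 3-hydroxyphenyl on an aromatic carbon, which is the same kind of change as the one from compound 1 to compound 2, though the surroundings are not identical: in the earlier case the site was meta to a 3-hydroxyphenyl group and meta to a furan-2-yl group, whereas here it is meta to a 4-hydroxyphenyl group and meta to a pyridin-2-yl group. Because the earlier instance gave a 1.2-fold lower number from compound 1 to compound 2 (0.06 log units; within the scatter), the step from compound 3 to compound 4 is expected to be small as well, about a 1.1-fold lower number from compound 3 to compound 4 (0.06 log units; within the scatter). For compound 4 the estimate in this assay is therefore 1700 nM, with a likely range from 900 nM to 3500 nM. Whether the change behaves the same way on this core remains to be seen.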

Compound 4, half-maximal inhibitory concentration: > 50000 nM
Compound 4: only a limit was reported; the forecaster's own chance of this, stated with the estimate: 3%; middle value at least 29-fold (1.46 log units) from the limit.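

The swap of 3-hydroxyphenyl for 4-hydroxyphenyl did not carry over from one core to the other in this series, as the two instances of the change disagree: the same change on two cores in this assay, a 1.2-fold lower number (0.06 log units; within the scatter) from compound 1 to compound 2 and an at least 25-fold higher number (1.41 log units; beyond the scatter) from compound 3 to compound 4, at least 30-fold (1.47 log units) apart, beyond the scatter of two such steps

On the core of compound 3, the change gives an at least 25-fold higher number from compound 3 to compound 4 (1.41 log units; beyond the scatter), but the reading for compound 4 is a limit of the assay and not a number, so the size of this step is bounded on one side only: the limit of > 50000 nM in this assay, at which 1 of the 4 values shown sits.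

The two instances show that the near-silent result on the core of compound 1 was no safe guide to the core of compound 3, but they do not show which difference in the surroundings matters, since the furan-2-yl group gives way to pyridin-2-yl and the remaining 3-hydroxyphenyl group gives way to 4-hydroxyphenyl together.

The compounds shown leave open how a core carrying a furan-2-yl group with two 4-hydroxyphenyl groups would read, which would help separate those two differences. Also open, on these data alone, is whether a methoxy group or an amine in place of the hydroxyl groups, or a thiophen-2-yl group in place of pyridin-2-yl, would track compound 3 or compound 4.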